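Shortening the ester chain: compound 2 to compound 3

The source may report more compounds than this note shows. Statements on the series, on what has been measured and on what is new or still open speak of the compounds shown alone.

Measured so far in a functional assay on MDA-MB-231 cells (Homo sapiens) for cytotoxicity; on this read-out lower numbers stand for stronger inhibition and higher numbers for weaker inhibition:
- compound 1, `CCCCCCC(=O)Oc1ccc(/C=N/Cc2cccnc2)cc1`, 15000 nM
- compound 2, `CCCCCCCCCCCC(=O)Oc1ccc(/C=N/Cc2cccnc2)cc1`, 18900 nM

Going by the values given here, only two compounds have been measured, and they share one core, differing only in the length of the saturated chain on the ester. Compound 2 and compound 1 lie within the scatter of each other, as the step of a 1.3-fold higher number from compound 1 to compound 2 (0.10 log units; within the scatter) shows, so neither can be called stronger or weaker.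

Compound 3, `CCCCCCCC(=O)Oc1ccc(/C=N/Cc2cccnc2)cc1`, is the next compound in the series. It differs from compound 2 by hydrogen in place of butyl on a saturated chain carbon, seven bonds along the chain from a carbonyl carbon, which places its chain length between those of compound 1 and compound 2. Among the compounds with values here, the one step that bears on this change, a 1.3-fold higher number from compound 1 to compound 2 (0.10 log units; within the scatter), lies within the scatter, so no shift beyond the scatter is expected in this assay from compound 2 to compound 3, a 1.1-fold lower number from compound 2 to compound 3 (0.06 log units; within the scatter). Compound 3 is therefore estimated at 16500 nM, within a range from 8000 nM to 35000 nM.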

Compound 3, half-maximal inhibitory concentration: 15800 nM
For compound 3 the middle estimate is 1.0-fold (0.02 log units) above the measured one, and the stated range covers the measured number.
By their numbers in this assay, from the lowest: compounds 1, 3 and 2 (each within the scatter of the next).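

In this assay, hydrogen in place of butyl on a saturated chain carbon, seven bonds along the chain from a carbonyl carbon, gives a 1.2-fold lower number from compound 2 to compound 3 (0.08 log units; within the scatter) and the step from the shorter chain gives a 1.1-fold higher number from compound 1 to compound 3 (0.02 log units; within the scatter) in the same assay. Going by these compounds alone, the earlier pair offered only one comparison, whereas three chain lengths on the ester now give numbers that cannot be told apart, whether the change is a single methyl or a whole butyl. No measurement available here explains this level response.

On these data alone, it remains open whether a much shorter chain, such as an acetyl ester, would move the number beyond the scatter. The same holds for an amine or a carboxylic acid at the end of the chain.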